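A few compounds are considered here, and "the series" means these few. Any claim that something is new, unique, unknown or untested is made for them only; others in the source may bear on it.

Of the compounds shown here, two with a shared core have been read so far in an ADME assay on L6 cells (Rattus norvegicus) for cytotoxicity; on this read-out higher numbers stand for weaker inhibition and lower numbers for stronger inhibition. Among the compounds with values here, compound 1 `Cn1c2ccc([N+](=O)[O-])cc2c(=O)n1Cc1ccccc1` gives 43400 nM, and compound 2 `CCCn1c2ccc([N+](=O)[O-])cc2c(=O)n1Cc1ccccc1` gives 77400 nM, so compound 2 stands within the usual scatter of the only other number available. The next compound is compound 3 `O=c1c2cc([N+](=O)[O-])ccc2n(Cc2ccccc2)n1Cc1ccccc1`. Its change from compound 2 is phenyl in place of ethyl on a saturated chain carbon bound to an aromatic nitrogen, or, cut one bond further out, propyl to benzyl (phenyl in place of ethyl on a saturated chain carbon bound to an aromatic nitrogen). Within the data shown here, only one measured step bears on this. It touched the same kind of carbon: ethyl in place of hydrogen gave a 1.8-fold higher number from compound 1 to compound 2 (0.25 log units; within the scatter). That step moved the number no further than repeat measurements do. It brought in no ring, however, whereas phenyl does, so a single small step is thin support for a forecast. No clear shift in either direction is expected, and the expected change is a 1.4-fold lower number from compound 2 to compound 3 (0.15 log units; within the scatter). Compound 3 is estimated at 55000 nM, with an expected range from 18000 nM to 160000 nM.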

Compound 3, half-maximal inhibitory concentration: 37300 nM
Beside the measured number, compound 3's estimate is 1.5-fold (0.17 log units) above it; low and high end bracket the measured number.
By their numbers in this assay, from the lowest: compounds 3, 1 and 2 (each within the scatter of the next, the first and the last beyond it).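

In this assay, within the data shown here, the swap of ethyl for phenyl on this saturated chain carbon bound to an aromatic nitrogen produces the first step that clears the usual scatter, though only modestly (a 2.1-fold lower number from compound 2 to compound 3 (0.32 log units; beyond the scatter)). The same ring judged against the smallest group in the set tells a different story: phenyl in place of hydrogen stays within the scatter (a 1.2-fold lower number from compound 1 to compound 3 (0.07 log units; within the scatter)), so the size of the effect depends on which compound serves as the reference, and adding a ring here does not by itself shift the number clearly. No measurement is available that would explain why the phenyl and ethyl compounds differ.

From the compounds shown here alone, all three compounds carry only carbon and hydrogen in the group at this position, so it remains open how an amine, a carboxylic acid or a longer chain there would read out. The second benzyl group and the nitro group are the same throughout, which leaves their contribution to these numbers unknown, and three compounds are too few to show a trend with group size.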